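This account rests on a few compounds, and the source may have more. Where it says the series, first, only, none or still open, it means among the compounds named here.

Measured compounds in a functional assay on A549 cells (Homo sapiens) for cytotoxicity, read by MTT assay, with a stated time of 72 h; on this read-out lower numbers stand for stronger inhibition and higher numbers for weaker inhibition:
- compound 1 `CN(C)CCn1cnnc1-c1cc(Oc2ccc(NC(=O)N/N=C/c3ccc(Cl)cc3Cl)cc2F)ccn1` gives 810 nM
- compound 2 `CN(C)CCn1cnnc1-c1cc(Oc2ccc(NC(=O)N/N=C/c3c[nH]c4ccccc34)cc2F)ccn1` gives 820 nM
- compound 3 `CN(C)CCn1cnnc1-c1cc(Oc2ccc(NC(=O)N/N=C/c3ccc(O)c(O)c3)cc2F)ccn1` gives > 100000 nM, which is a limit of the assay and not a number

Compound 1 and compound 2 sit close together; the step of a 1.0-fold higher number from compound 1 to compound 2 (0.01 log units; within the scatter) stays within the scatter. Compound 3 stands apart from both: in this assay compound 3 reaches only the limit (the limit of > 100000 nM in this assay, at which 1 of the 3 values shown sits), so only a bound is known for it. The steps of an at least 120-fold higher number from compound 1 to compound 3 (2.09 log units; beyond the scatter) and an at least 120-fold higher number from compound 2 to compound 3 (2.08 log units; beyond the scatter) are both large and point the same way, toward weaker inhibition.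

Compound 4 `CN(C)CCn1cnnc1-c1cc(Oc2ccc(NC(=O)N/N=C/c3cccc(Cl)c3Cl)cc2F)ccn1` differs from compound 3 by 2,3-dichlorophenyl in place of 3,4-dihydroxyphenyl on a carbon with a double bond to nitrogen. Among the compounds with values here, the group that enters is a dichlorophenyl, as in compound 1, which carries 2,4-dichlorophenyl at the same place, while the group that leaves is the one carried by compound 3. The two large steps into compound 3 therefore bear directly on this change, and a large step in the opposite direction, toward stronger inhibition, is expected in this assay, roughly an at least 110-fold lower number from compound 3 to compound 4 (2.04 log units; beyond the scatter). Compound 4 is estimated to give about 900 nM in this assay, with a likely range from 300 nM to 3000 nM.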

Compound 4, half-maximal inhibitory concentration: 1090 nM
Compound 4: the middle estimate sits 1.2-fold (0.08 log units) below what was measured; low and high end bracket the measured number.
By their numbers in this assay, from the lowest: compounds 1, 2 and 4 (each within the scatter of the next). At a limit, above all of these: compound 3.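

In this assay, the 2,3-dichlorophenyl and 2,4-dichlorophenyl groups give matching results at this place, with a 1.3-fold higher number from compound 1 to compound 4 (0.13 log units; within the scatter), so the activity of the dichlorophenyl compounds shown here does not hang on one arrangement of the chlorines. The 1H-indol-3-yl group also matches 2,3-dichlorophenyl, with a 1.3-fold higher number from compound 2 to compound 4 (0.12 log units; within the scatter), whereas exchanging 3,4-dihydroxyphenyl for 2,3-dichlorophenyl, which keeps the same aromatic ring and heavy-atom count but carries no hydrogen-bond donors, gives an at least 91-fold lower number from compound 3 to compound 4 (1.96 log units; beyond the scatter). That last step is only a bound, as compound 3 stands at a limit and not a number: the limit of > 100000 nM in this assay, at which 1 of the 4 values shown sits.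

The compounds shown do not separate the effect of the two hydroxyl groups from that of the chlorines. An unsubstituted phenyl, a phenyl with a single hydroxyl or a dimethoxyphenyl at this place could show how much of the gap each of these accounts for.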